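The compounds below may be only part of what the source reports. "The series", "measured", "known", "first", "only" and "open" are said of these compounds alone.

Among the measured compounds shown here, compound 3 `Cc1cc(SC(C)(C)C)c(S(C)(=O)=O)cc1C(=O)N=C(N)N` stands highest of the three numbers measured so far in a functional assay for inhibition of sodium/hydrogen exchanger (Oryctolagus cuniculus) (on this read-out lower numbers stand for stronger inhibition and higher numbers for weaker inhibition), giving 22 nM. Compound 1 `Cc1cc(-c2ccccc2)c(S(C)(=O)=O)cc1C(=O)N=C(N)N` gives 19 nM in this assay, and compound 2 `Cc1cc(-c2ccco2)c(S(C)(=O)=O)cc1C(=O)N=C(N)N` gives 16 nM. Compound 4 `Cc1cc(N2CCCC2)c(S(C)(=O)=O)cc1C(=O)N=C(N)N` differs from compound 3 in one place: pyrrolidin-1-yl in place of (tert-butyl)sulfanyl on an aromatic carbon. For the measured compounds named here, the steps that bear on this exchange are those at the same position, a 1.2-fold higher number from compound 1 to compound 3 (0.06 log units; within the scatter) and a 1.4-fold higher number from compound 2 to compound 3 (0.14 log units; within the scatter), both of which stay within the scatter. Because a 1.2-fold higher number from compound 1 to compound 3 (0.06 log units; within the scatter) and a 1.4-fold higher number from compound 2 to compound 3 (0.14 log units; within the scatter) show no movement beyond the scatter for either group tried there, compound 4 is expected to show no step beyond the scatter either, no change at the digits printed from compound 3 to compound 4 (within the scatter). Compound 4 is therefore estimated at 22 nM in this assay, with a range from 8 nM to 60 nM.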

Compound 4, half-maximal inhibitory concentration: 11 nM
The estimate for compound 4 lay 2.0-fold (0.30 log units) above the measured number; the range from low to high includes it.
By their numbers in this assay, from the lowest: compounds 4, 2, 1 and 3 (each within the scatter of the next).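

In this assay this aromatic carbon also accepts a non-aromatic ring attached through its nitrogen, with no step beyond the scatter: a 2.0-fold lower number from compound 3 to compound 4 (0.30 log units; within the scatter) and a 1.5-fold lower number from compound 2 to compound 4 (0.16 log units; within the scatter) and a 1.7-fold lower number from compound 1 to compound 4 (0.24 log units; within the scatter). The phenyl, furan-2-yl, (tert-butyl)sulfanyl and pyrrolidin-1-yl compounds therefore all lie within the scatter of one another, so the exchange to pyrrolidin-1-yl separates compound 4 from none of them. Nothing given here accounts for these numbers. Still open, from the compounds shown here alone, is whether an open-chain amine such as dimethylamino, or a carboxylic acid, at this carbon would stay within that scatter. Going by these compounds, a larger ring such as piperidine remains equally open.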